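The source may hold more compounds than are shown below. What is called first, only, known or untested is meant among the compounds shown, and "the series" means these compounds.

In an ADME assay on L6 cells (Rattus norvegicus) for cytotoxicity, read by resazurin assay, with a stated time of 72 h (a lower number here means a stronger inhibitor, a higher number a weaker inhibitor), compound 1 `CC(C)c1ccc(C(=O)NC(=O)c2ccccc2O)cc1` gives 19 ug/mL and compound 2 `O=C(NC(=O)c1ccccc1O)c1ccc(OCc2ccccc2)cc1` gives 64 ug/mL, the higher of the two numbers. Compound 3 `CCN(CC)c1ccc(C(=O)NC(=O)c2ccccc2O)cc1` carries diethylamino in place of benzyloxy on an aromatic carbon. Among the compounds with values here, the only measured step bearing on this is modest, a 3.4-fold higher number from compound 1 to compound 2 (0.53 log units; beyond the scatter), and it came with benzyloxy in place of isopropyl. Going by that step, a move of similar size towards a lower number is expected on losing benzyloxy, though diethylamino itself is untested. The estimated change is a 2.3-fold lower number from compound 2 to compound 3 (0.36 log units; beyond the scatter). Compound 3 is expected at 28 ug/mL, with an estimated range of 10 ug/mL to 70 ug/mL.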

Compound 3, half-maximal inhibitory concentration: 8.2 ug/mL
Compound 3: middle estimate off by 3.4-fold (0.53 log units), on the high side; measured number below the stated range.
By their numbers in this assay, from the lowest: compound 3; then compound 1; then compound 2.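

Diethylamino on this aromatic carbon does more than undo the benzyloxy effect: in this assay it brings a 7.8-fold lower number from compound 2 to compound 3 (0.89 log units; beyond the scatter), and it also goes past isopropyl, with a 2.3-fold lower number from compound 1 to compound 3 (0.36 log units; beyond the scatter), both steps beyond the scatter. The position therefore tolerates an amine and, among these three groups, gives its lowest number with it. Nothing available here explains this order.

On these data alone, it remains open whether a shorter amine such as dimethylamino, or a ring amine such as morpholine, would fall in the same range. As far as these compounds go, a carboxylic acid at this place is equally open.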